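The source may hold more compounds than are shown below. What is called first, only, known or untested is meant among the compounds shown, and "the series" means these compounds.

Compound 1 `Cc1ccc(-c2[nH]c3ccccc3c2C2=C(Br)C(=O)C(Br)=C(Br)C2=O)cc1` is placed by a limit alone: in a functional assay on MCF7 cells (Homo sapiens) for antiproliferative activity, read by CCK-8 assay, with a stated time of 48 h (a lower number here means a stronger inhibitor, a higher number a weaker inhibitor), compound 1 gives > 25 ug/mL, which is a limit of the assay and not a number (the limit of > 25 ug/mL in this assay, at which 1 of the 2 values shown sits). Compound 2 `Cc1[nH]c2ccccc2c1C1=C(Br)C(=O)C(c2c(C)[nH]c3ccccc23)=C(Br)C1=O`, the other measured member, gives 7 ug/mL in this assay. Compound 3 `COc1ccc2[nH]c(C)c(C3=C(Br)C(=O)C(c4c(-c5ccc(C)cc5)[nH]c5ccccc45)=C(Br)C3=O)c2c1` differs from compound 1 by 5-methoxy-2-methyl-1H-indol-3-yl in place of bromo on a double-bonded ring carbon. Among the compounds with values here, no measured step covers this change, so the value of compound 2 is the only guide. Compound 3 is expected to move beyond the scatter, a step of an at least 3.1-fold lower number from compound 1 to compound 3 (0.49 log units; beyond the scatter), to an estimated 8 ug/mL (range 3 ug/mL to 25 ug/mL).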

Compound 3, half-maximal inhibitory concentration: 2.56 ug/mL
For compound 3 the middle estimate is 3.1-fold (0.49 log units) above the measured one; measured number below the stated range.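

Replacing bromo with 5-methoxy-2-methyl-1H-indol-3-yl on this double-bonded ring carbon gives an at least 9.7-fold lower number from compound 1 to compound 3 (0.98 log units; beyond the scatter) in this assay. Within the data shown here, this position therefore accepts a much larger group, and here the large group goes with a stronger result, a change no earlier step covered. The step has no upper size, since the value of compound 1 is a limit and not a number: the limit of > 25 ug/mL in this assay, at which 1 of the 3 values shown sits.

From the compounds shown here alone, the share of the methoxy group in this step stays open. So does the outcome with a smaller group on this carbon, such as an amine or a carboxylic acid.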